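Urea aryl cap: ethynyl to methanesulfonamide

The source may hold more compounds than are shown below. What is called first, only, known or untested is meant among the compounds shown, and "the series" means these compounds.

compound 1 `Cc1ccc(NC(=O)Nc2cccc(-c3nc(-c4ccc(NC(=O)c5cccnc5)cc4Cl)no3)c2)cc1`: 3500 nM
compound 2 `C#Cc1ccc(NC(=O)Nc2cccc(-c3nc(-c4ccc(NC(=O)c5cccnc5)cc4Cl)no3)c2)cc1`: > 10000 nM

In a functional assay on MDA-MB-231 cells (Homo sapiens) for antiproliferative activity, read by MTT assay, with a stated time of 72 h (on this read-out higher numbers stand for weaker inhibition and lower numbers for stronger inhibition), compound 1 gives 3500 nM. Compound 2 reaches only a limit of the assay, > 10000 nM (the limit of > 10000 nM in this assay, at which 1 of the 2 values shown sits). Going by the values given here, the single measured step, an at least 2.8-fold higher number from compound 1 to compound 2 (0.45 log units; beyond the scatter), runs toward weaker inhibition. Compound 3 `CS(=O)(=O)Nc1cccc(NC(=O)Nc2cccc(-c3nc(-c4ccc(NC(=O)c5cccnc5)cc4Cl)no3)c2)c1` differs from compound 2 by 3-(methanesulfonamido)phenyl in place of 4-ethynylphenyl on an amide-type nitrogen. Among the compounds with values here, no measured step covers this change, and the starting point is a limit, so the size and direction of the step are open. Compound 3 is expected near 8000 nM, with a range of 2500 nM to 25000 nM. This is an expected at least 1.2-fold lower number from compound 2 to compound 3 (0.09 log units; that floor lies within the scatter), with no step beyond the scatter claimed.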

Compound 3, half-maximal inhibitory concentration: > 10000 nM
Compound 3: no number, only a limit; the forecaster's own chance of this, stated with the estimate: 40%; at least 1.2-fold (0.09 log units) between middle value and limit.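

In this assay, 3-(methanesulfonamido)phenyl in place of 4-methylphenyl on the amide-type nitrogen gives an at least 2.8-fold higher number from compound 1 to compound 3 (0.45 log units; beyond the scatter). Two different replacements of 4-methylphenyl now lead to a limit, and compound 1 alone keeps a measurable value: the limit of > 10000 nM in this assay, at which 2 of the 3 values shown sit. The step from compound 2 to compound 3 cannot be read, as both values are limits.

Open, going by these compounds, is whether the methanesulfonamido group or its ring position drives the step from compound 1. Also open, on these data alone, is whether an amine on this aryl ring would match or improve on compound 1.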